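Moving the Hydroxyl Around the Benzyl Ring

The compounds below may be only part of what the source reports. "The series", "measured", "known", "first", "only" and "open" are said of these compounds alone.

Compound 1 `CC(C)C(CO)Nc1nc(NCc2ccc(O)cc2)c2ncn(C(C)C)c2n1` and compound 2 `CC(C)n1cnc2c(NCc3ccc(O)cc3)nc(NCCCO)nc21` share one core and differ only in the group on a nitrogen on an aromatic ring. In a functional assay on G-361 cells (Homo sapiens) for cytotoxicity (a higher number here means a weaker inhibitor, a lower number a stronger inhibitor), compound 1 gives 11100 nM, and compound 2 gives 23000 nM. Compound 1 thus stands lowest of the two numbers, and the step of a 2.1-fold higher number from compound 1 to compound 2 (0.32 log units; beyond the scatter) shows that this side-chain swap weakens inhibition modestly.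

Compound 3 `CC(C)C(CO)Nc1nc(NCc2ccccc2O)c2ncn(C(C)C)c2n1` has not yet been measured. It differs from compound 1 by 2-hydroxyphenyl in place of 4-hydroxyphenyl on a saturated chain carbon bound to a nitrogen on an aromatic ring; the two have the same atoms, joined differently.

Among the measured compounds shown here, no measured step bears on this change: the single step known concerns the side chain on the ring nitrogen, not the hydroxyphenyl group. There is therefore no direct guide, and the expectation rests on compound 1 alone, with added uncertainty. In this assay compound 3 is expected to give about 14000 nM, within a range from 4000 nM to 45000 nM. The expected step is a 1.3-fold higher number from compound 1 to compound 3 (0.10 log units; within the scatter), that is, no change beyond the scatter with the range left wide.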

Compound 3, half-maximal inhibitory concentration: 7800 nM
Compound 3: the middle estimate sits 1.8-fold (0.25 log units) above what was measured, and the stated range covers the measured number.
By their numbers in this assay, from the lowest: compounds 3 and 1 (each within the scatter of the next); then compound 2.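

In this assay, moving the hydroxyl from 4-hydroxyphenyl to 2-hydroxyphenyl, on a saturated chain carbon bound to a nitrogen on an aromatic ring, gives a 1.4-fold lower number from compound 1 to compound 3 (0.15 log units; within the scatter). Among the compounds shown here, the earlier step touched only the other side chain, so this is the first reading on the hydroxyphenyl group itself: with the same atoms joined differently, the two compounds cannot be told apart in this cell read-out. No measurement is available to explain why these two compounds read alike.

The compounds shown all carry a hydroxyl on this ring, so they leave open whether the hydroxyl matters at all, which a plain phenyl group or a methoxyphenyl group in the same place could test. As far as these compounds go, it also remains open whether the swap to 2-hydroxyphenyl would read the same alongside the 3-hydroxypropyl side chain of compound 2, or alongside a side chain ending in an amine or a carboxylic acid.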